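Swapping Methoxy for Ethyl on the Weakest Compound

This account rests on a few compounds, and the source may have more. Where it says the series, first, only, none or still open, it means among the compounds named here.

For the measured compounds named here, compound 1 `COc1cccc(Nc2nccc(-c3ccsc3)n2)c1` is the weakest inhibitor among the three compounds measured so far. In a functional assay for inhibition, with Homo sapiens as the target (a lower number here means a stronger inhibitor, a higher number a weaker inhibitor), compound 1 gives 1800 nM. Compound 2 `COc1cccc(Nc2nccc(-c3ccncc3)n2)c1` gives 400 nM in this assay, and compound 3 `COc1cccc(Nc2nccc(-c3ccccn3)n2)c1` gives 200 nM. Both differ from compound 1 only in one attached ring: a 4.5-fold lower number from compound 1 to compound 2 (0.65 log units; beyond the scatter) and a 9.0-fold lower number from compound 1 to compound 3 (0.95 log units; beyond the scatter), while a 2.0-fold lower number from compound 2 to compound 3 (0.30 log units; within the scatter) is too small to count as a real difference.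

Compound 4 `CCc1cccc(Nc2nccc(-c3ccsc3)n2)c1` takes a different route. It keeps the thiophen-3-yl ring of compound 1 and alters the methoxy group instead: ethyl in place of methoxy on an aromatic carbon. Going by the values given here, none of the measured steps touches this group; all three exchange one attached ring for another and leave the methoxy untouched, so they give no direct guidance on how methoxy against ethyl plays out in this assay. With nothing to anchor a direction, the plainest expectation is no step beyond the scatter, though the range must be set wide to reflect that uncertainty. Compound 4 is therefore estimated at 1800 nM, with a range from 600 nM to 5400 nM. The expected step of no change at the digits printed from compound 1 to compound 4 (within the scatter) is essentially flat.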

Compound 4, half-maximal inhibitory concentration: 1100 nM
Compound 4: the middle estimate sits 1.6-fold (0.21 log units) above what was measured, and the stated range covers the measured number.
By their numbers in this assay, from the lowest: compounds 3 and 2 (each within the scatter of the next); then compounds 4 and 1 (each within the scatter of the next).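

At this place on the ring, meta to a large group, ethyl in place of methoxy gives a 1.6-fold lower number from compound 1 to compound 4 (0.21 log units; within the scatter) in this assay, so compound 1 and compound 4 cannot be told apart. The earlier steps shown here all exchanged the attached ring, while this pair shows that, with the thiophen-3-yl ring in place, the methoxy oxygen and its one hydrogen-bond acceptor can give way to the carbon-only ethyl with no change beyond the scatter. No measurement here explains why these two groups read alike.

Whether ethyl and methoxy also read alike with a pyridin-4-yl or pyridin-2-yl ring in place stays open, as the compounds shown hold this exchange only with the thiophen-3-yl ring. Also open, going by these compounds, is how a group of a different kind would read at this place, such as an amine, a carboxylic acid or a longer chain like butyl, as methoxy and ethyl have the same count of heavy atoms and show nothing about larger groups.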